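Ring Swap on the Amide Carbonyl: Canine Half-Life

This account rests on a few compounds, and the source may have more. Where it says the series, first, only, none or still open, it means among the compounds named here.

Compound 1 `CCn1ncc(-c2nc3c(N4CCC(n5c(=O)[nH]c6ncccc65)CC4)ncnc3n2C)c1C`: 1.1 h
Compound 2 `CCn1ncc(-c2nc3c(O[C@H]4CCN(C(=O)C5CC5)C4)ncnc3n2C)c1C`: 2.7 h

In an ADME assay (Canis lupus familiaris, strain Beagle) for metabolic stability (a lower number here means that the compound disappears faster, a higher number that the compound lasts longer), compound 2 gives the higher of the two half-lives, 2.7 h, while compound 1 gives 1.1 h. Compound 3 `CCn1ncc(-c2nc3c(O[C@H]4CCN(C(=O)C5CCOCC5)C4)ncnc3n2C)c1C` differs from compound 2 in one place: oxan-4-yl in place of cyclopropyl on a carbonyl carbon. Within the data shown here, no measured pair shows this change, so its effect on the half-life is unknown. The step of a 1.1-fold lower number from compound 2 to compound 3 (0.03 log units; within the scatter) is expected to stay within the scatter, in either direction. The half-life of compound 3 is estimated at 2.5 h, with a range from 1.2 h to 5 h.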

Compound 3, half-life: 1.5 h
Compound 3: middle estimate off by 1.7-fold (0.22 log units), on the high side, and the stated range covers the measured number.
By their numbers in this assay, from the lowest: compounds 1, 3 and 2 (each within the scatter of the next, the first and the last beyond it).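

Among these compounds, the first measured pair at this position shows that, in this assay, oxan-4-yl in place of cyclopropyl on a carbonyl carbon gives a 1.8-fold lower number from compound 2 to compound 3 (0.26 log units; within the scatter). On this pair, then, the amide carbonyl carries a six-membered ring with one oxygen as well as a three-membered carbon ring, with no step beyond the scatter. Nothing measured here speaks to a cause for this step. Open, from the compounds shown here alone, is whether a cyclohexyl group, which would separate ring size from the ring oxygen, would give a similar half-life. Also open, going by these compounds, is whether an amine or a longer chain on the same carbonyl carbon would move it beyond the scatter.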